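The source may hold more compounds than are shown below. What is called first, only, known or untested is meant among the compounds shown, and "the series" means these compounds.

Measured in a functional assay on HeLa cells (Homo sapiens) for cytotoxicity, read by cell counting, with a stated time of 4 days; on this read-out lower numbers stand for stronger inhibition and higher numbers for weaker inhibition:

compound 1, `C=C(Br)C(=O)Nc1ccc(/C=C2\SC(=O)N(Cc3ccccc3)C2=O)cc1`, gives 1000 nM.
compound 2, `C=C(Br)C(=O)Nc1ccc(/C=C2\SC(=O)N(Cc3ccc(C(F)(F)F)cc3)C2=O)cc1`, gives 13000 nM.
compound 3, `Nc1cccc(/C=C2\SC(=O)N(Cc3ccccc3)C2=O)c1`, gives only a limit of the assay, > 250000 nM.

Compound 2 differs from compound 1 by one change, (trifluoromethyl in place of hydrogen on an aromatic carbon), and that change gave a 13-fold higher number from compound 1 to compound 2 (1.11 log units; beyond the scatter), so compound 2 is the weaker of the two in this assay. The core of compound 3 differs from the core of compound 1 in a way that is not broken down here; its value sits at the limit of > 250000 nM in this assay, at which 1 of the 3 values shown sits, so only a limit is known for it.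

Compound 4, `Nc1cccc(/C=C2\SC(=O)N(Cc3ccc(C(F)(F)F)cc3)C2=O)c1`, is still to be measured. For the measured compounds named here, it differs from compound 3 by trifluoromethyl in place of hydrogen on an aromatic carbon, the same change as the one between compound 1 and compound 2, placed in the same way. Going from compound 3 to compound 4, a step that the limit leaves unreadable from compound 3 to compound 4 is expected, resting on a 13-fold higher number from compound 1 to compound 2 (1.11 log units; beyond the scatter) seen between compound 1 and compound 2. Since compound 3 is already at a limit, compound 4 is expected to be reported as a limit too, with an estimate of 1000000 nM, between 250000 nM and 5000000 nM.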

Compound 4, half-maximal inhibitory concentration: > 250000 nM
Compound 4: no number, only a limit; the forecaster's own chance of this, stated with the estimate: 90%; the middle value does not contradict the limit.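

No size can be read for the step from compound 3 to compound 4, the swap of hydrogen for trifluoromethyl, because both compounds sit at a limit and give no number: the limit of > 250000 nM in this assay, at which 2 of the 4 values shown sit.

The compounds shown leave open whether this swap weakens compound 3 as it weakened compound 1.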